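Methoxy for trifluoromethyl on the sulfonyl aryl of compound 2

This account rests on a few compounds, and the source may have more. Where it says the series, first, only, none or still open, it means among the compounds named here.

Compound 2 `O=S(=O)(Nc1ccc2oc(-c3ccccc3)nc2c1)c1ccccc1C(F)(F)F` is one of three measured members of the series. In an assay on cells for inhibition of HSP60/HSP10 (Homo sapiens), with a stated time of 60 min (on this read-out higher numbers stand for weaker inhibition and lower numbers for stronger inhibition), compound 2 gives only a limit, > 100000 nM, so its standing on the numbers is known only as the limit at which it sits (the limit of > 100000 nM in this assay, at which 1 of the 3 values shown sits). The two compounds with numbers are compound 1 `O=S(=O)(Nc1ccc(-c2nc3ccccc3o2)cc1)c1cccs1`, which in this assay gives 63000 nM, and compound 3 `O=S(=O)(Nc1ccc(-c2nc3ccccc3o2)cc1)c1cccc(O)c1`, which in this assay gives 62000 nM. Among the measured compounds shown here, the one measured step, a 1.0-fold lower number from compound 1 to compound 3 (0.01 log units; within the scatter), changes the group on the sulfonyl sulfur and lies within the scatter.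

Compound 4 `COc1ccccc1S(=O)(=O)Nc1ccc2oc(-c3ccccc3)nc2c1` is not yet measured. It differs from compound 2 by methoxy in place of trifluoromethyl on an aromatic carbon. For the measured compounds named here, no measured step changes a group at this place; the only measured step concerns a different place and was within the scatter, so none of the measured steps bears directly on this change. Compound 2 itself sits at a limit, so the starting point is not a number. The expectation for compound 4 can therefore rest only on the weak values across the series and on the limit of compound 2; no step beyond the scatter is expected in this assay, in either direction. Compound 4 is expected to come out near 100000 nM, within 40000 nM to 250000 nM, and may again be reported only as a limit. The step this estimate means, a number no higher from compound 2 to compound 4 (the limit leaves the size open), is expected to lie within the scatter.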

Compound 4, half-maximal inhibitory concentration: > 100000 nM
Compound 4: no number, only a limit (the forecaster's own chance of this, stated with the estimate: 55%); the middle value sits exactly at the limit.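

In this assay, compound 2 and compound 4 each stand only at a limit, so no step can be read between them: the limit of > 100000 nM in this assay, at which 2 of the 4 values shown sit.

The compounds shown leave open how methoxy and trifluoromethyl on this aromatic carbon compare in this assay, and whether any group at this place on the core of compound 2 gives a number there.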